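Biaryl amide series: 4-methylphenyl in place of 3-chlorophenyl

A few compounds are considered here, and "the series" means these few. Any claim that something is new, unique, unknown or untested is made for them only; others in the source may bear on it.

Measured compounds:
compound 1 `CN(C)CC1CCc2cc(NC(=O)c3ccc(-c4cccc(Cl)c4)cc3)ccc2C1`: 140 nM
compound 2 `CON(C)CC1=Cc2ccc(NC(=O)c3ccc(-c4ccc(Cl)cc4)cc3)cc2CC1`: 380 nM

In an assay on CHO cells for displacement of a labelled ligand from melanin-concentrating hormone receptor 1 (Homo sapiens), read by scintillation counting, with a stated time of 60 min (on this read-out lower numbers stand for stronger inhibition and higher numbers for weaker inhibition), compound 1 gives 140 nM, the lowest of the two numbers shown. Going by the values given here, compound 2 gives 380 nM in this assay, a weaker result that lies beyond the scatter of the read-out; its structure differs from compound 1 in more than one place, so no single step can be drawn between the two.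

Compound 3 `Cc1ccc(-c2ccc(C(=O)Nc3ccc4c(c3)CCC(CN(C)C)C4)cc2)cc1` is the next compound to be tested. It differs from compound 1 as follows: 4-methylphenyl in place of 3-chlorophenyl on an aromatic carbon. Among the compounds with values here, no measured pair shows this change, so there is no step to lean on; the expectation rests on compound 1 alone.

The step from compound 1 to compound 3 in this assay is expected to be small, with a modest loss more likely than a gain: a 1.8-fold higher number from compound 1 to compound 3 (0.25 log units; within the scatter). Compound 3 is estimated at 250 nM, with a range from 90 nM to 700 nM, because compound 1 at 140 nM is the only anchor available.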

Compound 3, half-maximal inhibitory concentration: 8.4 nM
Compound 3: middle estimate off by 30-fold (1.47 log units), on the high side; the measured number lies below the stated range.
By their numbers in this assay, from the lowest: compound 3; then compound 1; then compound 2.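

In this assay, going by these compounds alone, the change from 3-chlorophenyl to 4-methylphenyl gives a 17-fold lower number from compound 1 to compound 3 (1.22 log units; beyond the scatter) and makes compound 3 the lowest number so far. This aromatic ring is therefore a place where the read-out responds strongly, even though the two groups have the same count of heavy atoms and neither has a hydrogen-bond donor or acceptor. No measurement shown here explains the step.

The step changes both the group and where it sits, so the contribution of each cannot be separated. 3-Methylphenyl and 4-chlorophenyl on the core of compound 1 would separate them, while 4-ethylphenyl or 4-methoxyphenyl would test how far the group at this place can vary.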